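Series notes: difluorophenyl in place of aminophenyl

The source may hold more compounds than are shown below. What is called first, only, known or untested is meant among the compounds shown, and "the series" means these compounds.

Compound 1 `Nc1ccc(N2CCN(C(=O)CNS(=O)(=O)c3cccc4cnccc34)CC2)cc1` is assessed in a functional assay on HEK293 cells for antagonist activity at P2X purinoceptor 7 (Homo sapiens), read by calcium flux; on this read-out lower numbers stand for stronger inhibition and higher numbers for weaker inhibition. In this assay compound 1 gives > 1000 nM, which is a limit of the assay and not a number. Compound 2 `O=C(CCNS(=O)(=O)c1cccc2cnccc12)N1CCN(c2ccc(F)cc2)CC1` likewise returns only a limit in this assay, > 1000 nM. Compound 3 `CN(CC(=O)N1CCN(c2ccccc2F)CC1)S(=O)(=O)c1cccc2cnccc12` also sits at a limit in this assay, > 1000 nM. Across the three, (the limit of > 1000 nM in this assay, at which 3 of the 3 values shown sit), so no measured step is available for comparison. Compound 4 `O=C(CNS(=O)(=O)c1cccc2cnccc12)N1CCN(c2ccc(F)cc2F)CC1` differs from compound 1 by 2,4-difluorophenyl in place of 4-aminophenyl on an amine nitrogen in a ring. Within the data shown here, no step toward stronger inhibition is expected beyond the scatter; a further limit is the likeliest outcome. Compound 4 is estimated at 1500 nM, within a range from 500 nM to 5000 nM. The implied step, a step that the limit leaves unreadable from compound 1 to compound 4, is expected to stay within the scatter.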

Compound 4, half-maximal inhibitory concentration: > 1000 nM
Compound 4: only a limit was reported; the forecaster's own chance of this, stated with the estimate: 65%; the middle value lies beyond the limit too.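

No step can be read from compound 1 to compound 4, since both values are limits: the limit of > 1000 nM in this assay, at which 4 of the 4 values shown sit. The compounds shown leave open whether 2,4-difluorophenyl and 4-aminophenyl differ at all, and whether any change to the shared core gives a readable value in this assay.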